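The source may hold more compounds than are shown below. What is called first, only, known or untested is meant among the compounds shown, and "the series" means these compounds.

The series shares one core, and an ADME assay on cells (Splenocyte, Mus musculus, strain BALB/c) for cytotoxicity, read by CCK-8 assay, with a stated time of 48 h (a higher number here means that more compound is tolerated, a lower number that less compound is tolerated), is the measure that ties its members together. Compound 1, `COc1cc(-c2noc(Cc3c[nH]c4ccccc34)n2)cc(OC)c1OC`, gives > 50000 nM in this assay, which is a limit of the assay rather than a number. Compound 2, `c1ccc(-c2noc(Cc3c[nH]c4ccccc34)n2)cc1`, gives > 50000 nM in this assay, again a limit and not a number. Where compound 2 stands is therefore told only by that limit: both values obtained so far sit at the same edge of this assay, as the limit of > 50000 nM in this assay, at which 2 of the 2 values shown sit, shows, and on these numbers compound 1 and compound 2 cannot be told apart.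

Compound 3, `Fc1ccc(-c2noc(Cc3c[nH]c4ccccc34)n2)cc1`, differs from compound 2 in one place: fluoro in place of hydrogen on an aromatic carbon. Among the measured compounds shown here, no measured step in this set covers a change of that kind, so the numbers offer no size to anticipate. In this assay the step is expected to be a number no higher from compound 2 to compound 3 (the limit leaves the size open), none beyond the usual scatter. Compound 3 is estimated to give 50000 nM in this assay, with a range from 25000 nM to 100000 nM, most likely reported again only as a limit.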

Compound 3, half-maximal cytotoxic concentration: 13600 nM
Estimate against measurement, compound 3: 3.7-fold (0.57 log units) above; the whole stated range lies above it.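

In this assay, the change from phenyl to 4-fluorophenyl brings an at least 3.6-fold lower number from compound 2 to compound 3 (0.56 log units; beyond the scatter), which makes this place, on an aromatic carbon para to a large group, the first shown to move the read-out in this series. A single fluorine atom, entering with no ring and no net charge, is enough here to turn a result at the edge of the assay into a number, so that less of compound 3 is tolerated by these cells than the limit for compound 2 would allow. The step can only be read as a minimum, and its real size stays open, because compound 2 is known only as a limit: the limit of > 50000 nM in this assay, at which 2 of the 3 values shown sit.

What the compounds shown leave open is whether this shift belongs to fluoro in particular, since nothing tells how a chloro group, a methyl group or an amine at the same place would read. They also leave open whether the same exchange would count for as much on the trimethoxy-substituted ring of compound 1, or at another carbon of the ring in compound 2.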